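Working notes on an amide series in the tail flick test

This account rests on a few compounds, and the source may have more. Where it says the series, first, only, none or still open, it means among the compounds named here.

Measured so far:
compound 1, `NC(=O)CC[C@H](NC(=O)CN(c1ncnc2c1ncn2C1CCCCO1)C1CC1)C(=O)OCc1ccccc1`, 39.4%
compound 2, `C[C@H](NC(=O)CN(c1nc(Cl)nc2[nH]cnc12)C1CC1)C(=O)OCc1ccccc1`, 64.3%
compound 3, `O=C(O)[C@@H]1CCCN1C(=O)CN(c1nc(Cl)nc2[nH]cnc12)C1CC1`, 34.9%

In a functional assay on the whole organism (Tail, strain ICR) with Mus musculus as the target, in the tail flick test, with a stated time of 60 min, at a dose of 25 umol/kg by the oral route (on this read-out lower numbers stand for a weaker effect and higher numbers for a stronger effect at the one dose given), compound 2 gives 64.3%, the highest of the three numbers. Compound 1 gives 39.4% and compound 3 gives 34.9%; both gaps to compound 2 lie beyond the scatter. Compound 4, `O=C(CN(c1nc(Cl)nc2[nH]cnc12)C1CC1)N[C@@H](CC(=O)OCc1ccccc1)C(=O)OCc1ccccc1`, has not yet been measured. It differs from compound 2 as follows: benzyloxycarbonyl in place of hydrogen on a saturated chain carbon, two bonds along the chain from an amide-type nitrogen and a carbonyl carbon. Among the measured compounds shown here, no step between measured compounds isolates this change, so the expectation rests on the standing of compound 2 alone, with the two other measured compounds sitting lower. A modest downward step is expected, likely at the edge of the scatter. Compound 4 is expected to give 50%, within 30% to 70%, which means an estimated step of a number 14.3 percentage points lower from compound 2 to compound 4 (beyond the scatter).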

Compound 4, a percentage reported as activity, at one dose (the size of the read-out at that dose, not a potency): 22.4%
Estimate against measurement, compound 4: 27.6 percentage points above; the whole stated range lies above it.
By their numbers in this assay, from the lowest: compound 4; then compounds 3 and 1 (each within the scatter of the next); then compound 2.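

In this assay, among the compounds shown here, this saturated chain carbon, two bonds along the chain from an amide-type nitrogen and a carbonyl carbon, proves sensitive to substitution: benzyloxycarbonyl in place of hydrogen gives a number 41.9 percentage points lower from compound 2 to compound 4 (beyond the scatter), the only single-place step so far. The change from methyl to (benzyloxycarbonyl)methyl is therefore not tolerated at this dose. Nothing in hand accounts for the size of this step.

Open, going by these compounds, is whether a free carboxylic acid or a primary amide on the same chain would hold the number of compound 2. An ethyl group at this carbon would test whether chain length alone matters.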